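This account rests on a few compounds, and the source may have more. Where it says the series, first, only, none or still open, it means among the compounds named here.

Working notes on the series, all read in a functional assay on SH-SY5Y cells (Homo sapiens) for cytotoxicity, read by MTT assay, with a stated time of 72 h; a higher number here means a weaker inhibitor, a lower number a stronger inhibitor. Compound 1 (`CN1CCN(CCCCn2c3c(c4ccccc42)C(=O)c2c[n+]([O-])c4ccccc4c2C3=O)CC1`) gives 100 nM, compound 2 (`O=C1c2c[n+]([O-])c3ccccc3c2C(=O)c2c1c1ccccc1n2CCN1CCCC1`) gives 520 nM, and compound 3 (`O=C1c2c[n+]([O-])c3ccccc3c2C(=O)c2c1c1ccccc1n2CCCCN1CCCCC1`) gives 230 nM. Compound 3 therefore holds the middle place of the three, and its gaps to both others lie beyond the scatter.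

The next compound is compound 4 (`CN1CCN(CCCCCCn2c3c(c4ccccc42)C(=O)c2c[n+]([O-])c4ccccc4c2C3=O)CC1`). The change is 2-(4-methylpiperazin-1-yl)ethyl in place of piperidin-1-yl on a saturated chain carbon, four bonds along the chain from an aromatic nitrogen, which puts 2-(4-methylpiperazin-1-yl)ethyl in place of piperidin-1-yl on a saturated chain carbon, four bonds along the chain from an aromatic nitrogen.

Going by the values given here, the closest precedent is a 2.3-fold higher number from compound 1 to compound 3 (0.36 log units; beyond the scatter), a modest step with piperidin-1-yl in place of 4-methylpiperazin-1-yl at that same place. Compound 4 restores the 4-methylpiperazin-1-yl group, so this step points towards a lower number. Two further modest steps, a 5.2-fold higher number from compound 1 to compound 2 (0.72 log units; beyond the scatter) and a 2.3-fold lower number from compound 2 to compound 3 (0.35 log units; beyond the scatter), each change the ring and the chain together, so they bear on the question only loosely. Among the compounds with values here, no measured step changes the chain alone on a 4-methylpiperazin-1-yl compound, which leaves the outcome uncertain.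

A modest step towards a lower number is expected in this assay. The estimated step is a 2.3-fold lower number from compound 3 to compound 4 (0.36 log units; beyond the scatter). For compound 4 the estimated value is 100 nM, with an expected range of 35 nM to 280 nM.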

Compound 4, half-maximal inhibitory concentration: 920 nM
For compound 4 the middle estimate is 9.2-fold (0.96 log units) below the measured one, outside the stated range (above it).
By their numbers in this assay, from the lowest: compound 1; then compound 3; then compounds 2 and 4 (each within the scatter of the next).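

In this assay, 2-(4-methylpiperazin-1-yl)ethyl in place of 4-methylpiperazin-1-yl on a saturated chain carbon, four bonds along the chain from an aromatic nitrogen, gives a 9.2-fold higher number from compound 1 to compound 4 (0.96 log units; beyond the scatter), the only step shown that extends the chain while the terminal 4-methylpiperazine ring stays the same. The 4-methylpiperazine ring therefore does not carry a low number on its own: the change to the longer chain gives a 4.0-fold higher number from compound 3 to compound 4 (0.60 log units; beyond the scatter), and the further comparison gives a 1.8-fold higher number from compound 2 to compound 4 (0.25 log units; within the scatter), which leaves these two compounds level despite their different rings and chains. No measured evidence bears on the reason for this chain effect.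

The compounds shown leave open whether the effect of chain extension also holds with a different terminal ring, as a piperidin-1-yl group on the chain of compound 4 would test. They also leave open how a morpholin-4-yl group on the chain of compound 1 would compare with the 4-methylpiperazin-1-yl and piperidin-1-yl groups at this position.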